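This account rests on a few compounds, and the source may have more. Where it says the series, first, only, none or still open, it means among the compounds named here.

In a functional assay on A549 cells (Homo sapiens) for cytotoxicity, read by MTT assay, with a stated time of 72 h (a higher number here means a weaker inhibitor, a lower number a stronger inhibitor), compound 3 `Cc1ccc(-n2nc(C(=O)Nc3ccc(Oc4ncnc5c4ccn5C)c(F)c3)c(C)cc2=O)cc1` gives only a limit, > 60000 nM. Compound 2 `Cc1cc(=O)n(-c2cccc(F)c2)nc1C(=O)Nc1ccc(Oc2ncnc3c2ccn3C)c(F)c1` likewise gives only a limit, > 60000 nM. Both stand at the limit of > 60000 nM in this assay, at which 2 of the 3 values shown sit, so the step that the two limits leave unreadable from compound 2 to compound 3 cannot be read. Compound 1 `Cc1cc(=O)n(-c2ccccc2C(F)(F)F)nc1C(=O)Nc1ccc(Oc2ncnc3c2ccn3C)cc1` differs from the unmeasured compound by a single fluorine and gives 5860 nM in this assay. Compound 4 `Cc1cc(=O)n(-c2ccccc2C(F)(F)F)nc1C(=O)Nc1ccc(Oc2ncnc3c2ccn3C)c(F)c1` arises from compound 3 by 2-(trifluoromethyl)phenyl in place of 4-methylphenyl on an aromatic nitrogen. For the measured compounds named here, no measured step in this set is readable, so the only guide is compound 1 at 5860 nM, which carries the same 2-(trifluoromethyl)phenyl on the aromatic nitrogen. On that basis compound 4 is expected to leave the limit with a step of an at least 6.0-fold lower number from compound 3 to compound 4 (0.77 log units; beyond the scatter). The estimate for compound 4 in this assay is 10000 nM, ranging from 3000 nM to 60000 nM.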

Compound 4, half-maximal inhibitory concentration: 35400 nM
Estimate against measurement, compound 4: 3.5-fold (0.55 log units) below; measured number inside the range.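

In this assay, compound 4 shows that 2-(trifluoromethyl)phenyl on the aromatic nitrogen can bring a fluorinated compound to a readable number, but its comparison with the other two groups gives only floors: an at least 1.6-fold lower number from compound 3 to compound 4 (0.22 log units; that floor lies within the scatter) and an at least 1.6-fold lower number from compound 2 to compound 4 (0.22 log units; that floor lies within the scatter). These floors rest on limits rather than numbers: the limit of > 60000 nM in this assay, at which 2 of the 4 values shown sit. The fluoro in place of hydrogen on an aromatic carbon now has a measured size, a 6.0-fold higher number from compound 1 to compound 4 (0.78 log units; beyond the scatter), though only with this one group on the nitrogen.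

The compounds shown leave open whether that step holds with 4-methylphenyl or 3-fluorophenyl there. They also leave open how an amine or a carboxylic acid on that phenyl ring would read.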